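The source may hold more compounds than are shown below. What is called first, only, known or untested is meant among the compounds shown, and "the series" means these compounds.

The measured compounds, with their results in a functional assay on A549 cells (Homo sapiens) for cytotoxicity, read by MTT assay, with a stated time of 48 h; a lower number here means that less compound is needed, a higher number that more compound is needed for the effect:

Compound 1, `CO[C@H]1O[C@H](COc2ccc(-c3ccccc3)cc2)[C@@H](O)[C@H](O)[C@H]1Oc1ccccc1`, gives 36000 nM.
Compound 2, `CO[C@H]1O[C@H](COc2ccc(-c3ccccc3)cc2)[C@@H](O)[C@H](O)[C@H]1Oc1ccc(C(C)C)cc1`, gives 32000 nM.

Within the data shown here, compound 2 has the lowest of the two numbers, but its only neighbour is compound 1, and the step of a 1.1-fold lower number from compound 1 to compound 2 (0.05 log units; within the scatter) lies within the scatter, so the two compounds cannot be told apart on these data. Compound 3, `CO[C@H]1O[C@H](COc2ccc(-c3ccccc3)cc2)[C@@H](O)[C@H](O)[C@H]1Oc1cccc(C(C)C)c1`, keeps every atom of compound 2 and differs only in how they are joined: 3-isopropylphenyl in place of 4-isopropylphenyl on an oxygen on a saturated carbon. Among the measured compounds shown here, the one measured step, a 1.1-fold lower number from compound 1 to compound 2 (0.05 log units; within the scatter), shows that adding the isopropyl group at its present place leaves the number essentially unchanged. For the measured compounds named here, no measured pair shows what happens when the isopropyl group is moved to another place on the same ring, so the expectation rests on the one step alone. The estimate for compound 3 is therefore a step of a 1.0-fold higher number from compound 2 to compound 3 (0.01 log units; within the scatter), that is, no change beyond the scatter. Compound 3 is expected to give about 33000 nM in this assay, with a likely range from 15000 nM to 75000 nM.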

Compound 3, half-maximal effective concentration: 32000 nM
Beside the measured number, compound 3's estimate is 1.0-fold (0.01 log units) above it; the measured number falls inside the stated range.
By their numbers in this assay, from the lowest: compounds 2, 3 and 1 (each within the scatter of the next).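

In this assay, moving the isopropyl group on the ring, 3-isopropylphenyl in place of 4-isopropylphenyl on an oxygen on a saturated carbon, gives no change at the digits printed from compound 2 to compound 3 (within the scatter) and so adds the first measured information about where on this ring the group sits. Adding isopropyl at the new place, in place of a hydrogen on an aromatic carbon, gives a 1.1-fold lower number from compound 1 to compound 3 (0.05 log units; within the scatter), the same reading as the step already seen for the other place, so on these data compounds 1, 2 and 3 cannot be told apart and neither placement of this group separates from the ring that carries no isopropyl. The data offer no measurement that would explain why the three numbers stay together.

Going by these compounds, all three compounds carry either hydrogen or isopropyl on this phenyl ring, so it remains open whether a different group there, such as an amine, a carboxylic acid or a longer chain like hexyl, would produce a step beyond the scatter. The rest of the shared core is the same in all three, so the compounds shown also say nothing about how changes elsewhere would affect the number.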